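Removing the methyl from a mirror-image thymidine analogue

The compounds below may be only part of what the source reports. "The series", "measured", "known", "first", "only" and "open" are said of these compounds alone.

Measured in a functional assay on HT-29 cells (Homo sapiens) for cytotoxicity, read by MTT assay, with a stated time of 48 h; on this read-out lower numbers stand for stronger inhibition and higher numbers for weaker inhibition: compound 1, `Cc1cn([C@@H]2SC[C@@](C)(O)[C@H]2O)c(=O)[nH]c1=O`, 5000 nM; compound 2, `Cc1cn([C@H]2SC[C@](C)(O)[C@@H]2O)c(=O)[nH]c1=O`, 640000 nM.

Compound 2 stands highest of the two numbers. For the measured compounds named here, the only measured step is a 130-fold higher number from compound 1 to compound 2 (2.11 log units; beyond the scatter), which rests on (the fact that compounds 1 and 2 differ only in the configuration as drawn). Compound 3, `C[C@]1(O)CS[C@H](n2ccc(=O)[nH]c2=O)[C@H]1O`, differs from compound 2 by hydrogen in place of methyl on an aromatic carbon. Going by the values given here, no measured step touches this change, so no shift beyond the scatter is expected in this assay, though the range is left wide. Compound 3 is expected to give 640000 nM, between 100000 nM and 3000000 nM, a step of no change at the digits printed from compound 2 to compound 3 (within the scatter).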

Compound 3, half-maximal inhibitory concentration: 269000 nM
Beside the measured number, compound 3's estimate is 2.4-fold (0.38 log units) above it; low and high end bracket the measured number.
By their numbers in this assay, from the lowest: compound 1; then compound 3; then compound 2.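

In this assay, replacing the methyl on this aromatic carbon with hydrogen gives a 2.4-fold lower number from compound 2 to compound 3 (0.38 log units; beyond the scatter). The position therefore does respond to this change, and the methyl is not required for the cytotoxicity seen with compound 2, although the step is modest. Nothing in the data given explains the shift.

On these data alone, it remains open whether a larger ethyl group or a chlorine atom on this carbon would lower or raise the number. The same swap in the mirror-image compound 1 could also give a different step.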